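Replacing Isopropyl with Aziridin-1-yl on a Quinone Core

The compounds below may be only part of what the source reports. "The series", "measured", "known", "first", "only" and "open" are said of these compounds alone.

Two compounds sharing a bis-aziridinyl quinone core have numbers in a functional assay on L1210 cells (Mus musculus), with a stated time of 12 days; a higher number here means a more potent compound, by a factor of ten per unit of this negative logarithm, a lower number a less potent compound. Compound 1, `CCOC(COC(N)=O)C1=C(N2CC2)C(=O)C(C)=C(N2CC2)C1=O`, carries a carbamate-bearing side chain, and in this assay compound 1 gives 6.18. Compound 2, `CC1=C(N2CC2)C(=O)C(C(C)C)=C(N2CC2)C1=O`, carries instead an isopropyl group and a methyl group on the core, and in this assay compound 2 gives 5.6. Compound 2 thus stands lowest of the two, with compound 1 above it by a margin that lies beyond the usual scatter of this measurement.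

The step of interest leads from compound 2 to compound 3, `CC1=C(N2CC2)C(=O)C(N2CC2)=C(N2CC2)C1=O`. The change is aziridin-1-yl in place of isopropyl on a double-bonded ring carbon. Another aziridin-1-yl group thus enters the shared core where the isopropyl group stood.

Among the measured compounds shown here, no measured pair here shows the effect of such a change, so the expectation rests on the two numbers alone. The account expects a gain of a number 1.00 log units higher from compound 2 to compound 3 (beyond the scatter), lifting compound 3 above compound 2, in part because compound 1 already reaches 6.18 with a different substituent in that place. For compound 3 the estimate is 6.6, with a range from 5.9 to 7.3.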

Compound 3, logarithm of the reciprocal of the active concentration, log(1/C): 6.77
Compound 3: middle estimate off by 0.17 log units, on the low side; the measured number falls inside the stated range.
By their numbers in this assay, from the lowest: compound 2; then compound 1; then compound 3.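

In this assay, among the compounds shown here, aziridin-1-yl in place of isopropyl on a double-bonded ring carbon gives a number 1.17 log units higher from compound 2 to compound 3 (beyond the scatter), the first comparison in this set in which only one place differs. The step shows that the number is sensitive to the group at this position, next to the ring atom that bears an aziridin-1-yl group, even though the group that leaves and the group that enters have the same count of heavy atoms. No measurement shown here accounts for the size of this step, so the result stands as an observation without an established cause.

The compounds shown leave open whether the gain goes with the three-membered ring or with the nitrogen atom attached to the core, a question that a cyclopropyl group or a dimethylamino group on the same ring carbon would address. They also leave open whether aziridin-1-yl in place of the methyl group would move the number in this assay in the same direction, or by a similar amount.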